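The source may hold more compounds than are shown below. What is called first, only, known or untested is meant among the compounds shown, and "the series" means these compounds.

In a functional assay on the whole organism (strain albino) for inhibition, with Rattus norvegicus as the target, read by paw edema, with stated times of 30 min and 2 h, at a dose of 0.28 mmol/kg by the oral route (a higher number here means more inhibition at the dose given (going by the name of the read-out), a lower number less inhibition), compound 1 `C/C(=N\O)c1ccc(NC(=O)CSc2nnc(-c3ccccc3)n2-c2ccccc2)cc1` gives 52%, compound 2 `COc1ccc(-c2nnc(SCC(=O)Nc3ccc(/C(C)=N/O)cc3)n2-c2ccccc2)cc1` gives 56%, and compound 3 `CCn1c(SCC(=O)Nc2ccc(C(C)=O)cc2)nnc1-c1ccc(OC)c(OC)c1` gives 59%; the three numbers lie within the scatter of one another. Between compound 2 and compound 1 the change is hydrogen in place of methoxy on an aromatic carbon, and it made a number 4 percentage points lower from compound 2 to compound 1 (within the scatter). Compound 4 `CCn1c(SCC(=O)Nc2ccc(C(C)=O)cc2)nnc1-c1ccc(OC)cc1` has not yet been measured. It differs from compound 3 by hydrogen in place of methoxy on an aromatic carbon, the same kind of change, though here the place is ortho to a methoxy group and meta to a large group rather than para to a large group. How the cores of compound 3 and compound 2 differ is not broken down here. Because the earlier step read a number 4 percentage points lower from compound 2 to compound 1 (within the scatter), a step of a number 4 percentage points lower from compound 3 to compound 4 (within the scatter) is expected for compound 4. Compound 4 is therefore estimated at 55%, between 45% and 65%.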

Compound 4, a percentage reported as inhibition, in the whole organism at one dose (the size of the read-out at that dose, not a potency): 54%
The estimate for compound 4 lay 1 percentage points above the measured number, and the stated range covers the measured number.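

In this assay, hydrogen in place of methoxy, taking 3,4-dimethoxyphenyl to 4-methoxyphenyl, gave a number 5 percentage points lower from compound 3 to compound 4 (within the scatter). Set beside the earlier step, the change reads alike on the two cores: the same change on two cores in this assay, a number 4 percentage points lower (within the scatter) from compound 2 to compound 1 and a number 5 percentage points lower (within the scatter) from compound 3 to compound 4, 1 percentage points apart, within the scatter of two such steps. This shows that the change carried from one core to the other without a detectable difference, but with both steps within the scatter it does not show that the change alters inhibition on either core, nor that the agreement would hold on a third core.

The compounds shown leave open how an amine, a hydroxyl or a chlorine would read in place of the methoxy. They also leave open whether a carboxylic acid at that place would give a step beyond the scatter.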